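Swapping the aryl group on a shared core: compound 4

This account rests on a few compounds, and the source may have more. Where it says the series, first, only, none or still open, it means among the compounds named here.

Measured compounds so far:
- compound 1, `Oc1ccccc1/C=N/c1nnc(SCc2nnc(-c3ccc(Cl)cc3)o2)s1`, 2840 nM
- compound 2, `Cc1ccccc1-c1nnc(CSc2nnc(/N=C/c3ccccc3O)s2)o1`, 15500 nM
- compound 3, `Cc1ccc(-c2nnc(CSc3nnc(/N=C/c4ccccc4O)s3)o2)cc1`, 37100 nM

All three were tested in a functional assay on SMMC-7721 cells (Homo sapiens) for inhibition, read by CCK-8 assay; a higher number here means a weaker inhibitor, a lower number a stronger inhibitor. Compound 3 gives the highest number of the three: compound 2 stands nearest, as the step of a 2.4-fold higher number from compound 2 to compound 3 (0.38 log units; beyond the scatter) shows, and compound 1 furthest, as the step of a 13-fold higher number from compound 1 to compound 3 (1.12 log units; beyond the scatter) shows. Compound 1 to compound 2 is the remaining measured step, a 5.5-fold higher number from compound 1 to compound 2 (0.74 log units; beyond the scatter).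

The unmeasured compound 4 is `O=[N+]([O-])c1cccc(-c2nnc(CSc3nnc(/N=C/c4ccccc4O)s3)o2)c1`. It differs from compound 3 in one place: 3-nitrophenyl in place of 4-methylphenyl on an aromatic carbon. Among the measured compounds shown here, no measured step involves a nitro group, so direct guidance is lacking. What the measured steps do show is that changing the group on this phenyl ring moves the number well beyond the scatter, in both modest and large amounts. Because the step of a 13-fold higher number from compound 1 to compound 3 (1.12 log units; beyond the scatter) was large when chloro gave way to methyl, a change back to a different non-methyl group could well lower the number again, though the direction is uncertain.

For compound 4 the expected value in this assay is 12000 nM, with a range from 3000 nM to 45000 nM. This estimate corresponds to an expected step of a 3.1-fold lower number from compound 3 to compound 4 (0.49 log units; beyond the scatter).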

Compound 4, half-maximal inhibitory concentration: 15700 nM
For compound 4 the middle estimate is 1.3-fold (0.12 log units) below the measured one; low and high end bracket the measured number.
By their numbers in this assay, from the lowest: compound 1; then compounds 2 and 4 (each within the scatter of the next); then compound 3.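

In this assay, among the compounds shown here, the swap to 3-nitrophenyl gives a 2.4-fold lower number from compound 3 to compound 4 (0.37 log units; beyond the scatter) and shows that the phenyl group at this aromatic carbon can carry nitro, not only methyl or chloro, and still give a number within the range of the earlier compounds. Against 2-methylphenyl the same group gives a 1.0-fold higher number from compound 2 to compound 4 (0.01 log units; within the scatter) and so no separation, while 4-chlorophenyl keeps its lead, as a 5.5-fold higher number from compound 1 to compound 4 (0.74 log units; beyond the scatter) shows. Nothing at hand explains these differences.

On these data alone, whether an amine or a carboxylic acid on this phenyl ring could bring the number lower than 4-chlorophenyl does remains open. So does the part played by the place on the ring, which a pair such as 3-chlorophenyl and 4-nitrophenyl could help to separate from the part played by the group itself.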